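This account rests on a few compounds, and the source may have more. Where it says the series, first, only, none or still open, it means among the compounds named here.

The shared core is set out in compound 1, which is `CC(C)(C)OC(=O)Nc1ncc(C(Oc2ccc3cc(Br)ccc3c2)c2ccc(Cl)cc2)s1`; compound 2 is `O=C(Nc1ncc(C(Oc2ccc3cc(Br)ccc3c2)c2ccc(Cl)cc2)s1)C1CCOCC1` and compound 3 is `O=C(Nc1ncc(C(Oc2ccc3cc(Br)ccc3c2)c2ccc(Cl)cc2)s1)c1ccccc1`. In an ADME assay on HepG2 2.2.15 cells (Homo sapiens) for cytotoxicity (a lower number here means that less compound is tolerated, a higher number that more compound is tolerated), compound 1 reaches only the limit of > 50000 nM. Compound 2 is recorded in this assay as "not toxic" (no number reported). Compound 3 likewise stands in this assay at "not toxic" (no number reported), so it carries no single number of its own; of the three values shown, two are entries without a number. Across the series the only numeric anchor is the limit of > 50000 nM in this assay, at which 1 of the 3 values shown sits, belonging to compound 1. Compound 4 is `O=C(Nc1ncc(C(Oc2ccc3cc(Br)ccc3c2)c2ccc(Cl)cc2)s1)c1ccc(Cl)nc1`. It differs from compound 3 by 6-chloropyridin-3-yl in place of phenyl on a carbonyl carbon. Among the measured compounds shown here, no member of the series has yet yielded a numeric half-maximal cytotoxic concentration; no step beyond the scatter is expected in this assay in either direction. For compound 4 the expected value in this assay is 50000 nM, within 20000 nM to 100000 nM.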

Compound 4, half-maximal cytotoxic concentration: "not toxic" (no number reported)
Compound 4 has no reported number here, and the estimate cannot be compared.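

Compound 3 and compound 4 both carry no number in this assay; no step can be read between them. The compounds shown leave open any numeric half-maximal cytotoxic concentration for the series, whose only anchor is a limit: the limit of > 50000 nM in this assay, at which 1 of the 4 values shown sits.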